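Nitro on the phenyl of compound 3: expected effect

The source may hold more compounds than are shown below. What is called first, only, known or untested is meant among the compounds shown, and "the series" means these compounds.

Three compounds share one core and are compared in a functional assay on the whole organism (strain albino) for inhibition, with Rattus norvegicus as the target, read by paw edema, with a stated time of 1 h, at a dose of 20 mmol/kg by the intraperitoneal route; on this read-out lower numbers stand for less inhibition and higher numbers for more inhibition at the one dose given (going by the name of the read-out). Compound 1 `N#CC1=C(NCC(=O)N2CCCC2)N(c2ccccc2)C(=O)N2CCCCC(N3CCCC3)C12` gives 40.1%. Compound 2 `COc1ccc(N/C=N/C2=C(C#N)C3C(N4CCCC4)CCCCN3C(=O)N2c2ccccc2)cc1` gives 20.6%, and compound 3 `N#CC1=C(/N=C/c2ccccc2)N(c2ccccc2)C(=O)N2CCCCC(N3CCCC3)C12` gives 46.5%. Compound 3 sits at the upper end of these three numbers: the step of a number 25.9 percentage points higher from compound 2 to compound 3 (beyond the scatter) is beyond the scatter, while the step of a number 6.4 percentage points higher from compound 1 to compound 3 (within the scatter) is within it, so compound 3 and compound 1 cannot be told apart on this read-out.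

Compound 4 `N#CC1=C(/N=C/c2ccc([N+](=O)[O-])cc2)N(c2ccccc2)C(=O)N2CCCCC(N3CCCC3)C12` differs from compound 3 in one place: nitro in place of hydrogen on an aromatic carbon. Among the measured compounds shown here, no measured step in this set alters a substituent on that aromatic ring while leaving the rest untouched. The step of a number 19.5 percentage points lower from compound 1 to compound 2 (beyond the scatter) and the step of a number 25.9 percentage points higher from compound 2 to compound 3 (beyond the scatter) both exchange a whole group on the double-bonded ring carbon, and the step of a number 6.4 percentage points higher from compound 1 to compound 3 (within the scatter) does the same, so none of them speaks to a single nitro added on the ring. For the measured compounds named here, with no guiding precedent, the expectation for the step of a number 1.5 percentage points lower from compound 3 to compound 4 (within the scatter) is none beyond the scatter. Compound 4 is therefore estimated to give 45% in this assay, with a range from 30% to 60% expected.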

Compound 4, a percentage reported as inhibition, in the whole organism at one dose (the size of the read-out at that dose, not a potency): 66%
For compound 4 the middle estimate is 21 percentage points below the measured one; measured number above the stated range.
By their numbers in this assay, from the lowest: compound 2; then compounds 1 and 3 (each within the scatter of the next); then compound 4.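

In this assay, among the compounds shown here, the step of a number 19.5 percentage points higher from compound 3 to compound 4 (beyond the scatter) shows that the phenyl on the carbon with a double bond to nitrogen responds to a single added group, whereas the earlier steps exchanged whole groups and could not isolate a change on this ring. The 4-nitrophenyl compound also stands clear of the other two compounds, with the step of a number 25.9 percentage points higher from compound 1 to compound 4 (beyond the scatter) and the step of a number 45.4 percentage points higher from compound 2 to compound 4 (beyond the scatter) both lying beyond the scatter, so a nitro para to a large group separates compound 4 from compound 1, which compound 3 could not do on this read-out. Nothing in the data shown explains why the nitro raises the inhibition.

From the compounds shown here alone, it remains open whether this rise belongs to the nitro itself or would also follow from another group in the same place on the ring, such as an amine, a chlorine atom or a carboxylic acid. Going by these compounds, the read-out also comes from one dose at one time, so whether compound 4 stays ahead of compound 3 at other doses or times remains unknown.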